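The source may hold more compounds than are shown below. What is called first, only, known or untested is meant among the compounds shown, and "the series" means these compounds.

Working notes on the sulfonamide series. Compound 1 `COc1ccc(S(=O)(=O)Nc2ccc(-c3nc4ccccc4o3)cc2)cc1` joins a 4-methoxyphenyl sulfonyl group through a sulfonamide to the shared core. In an assay on isolated protein for inhibition of malate dehydrogenase, mitochondrial (Sus scrofa), with stated times of 45 min and 30 min (on this read-out lower numbers stand for stronger inhibition and higher numbers for weaker inhibition), compound 1 gives only a limit of the assay, > 63000 nM. Compound 2 `O=S(=O)(Nc1ccc(-c2nc3ccccc3o2)cc1)c1ccccc1O` carries a 2-hydroxyphenyl on the sulfonyl sulfur instead. In this assay compound 2 also gives only a limit, > 63000 nM. The step that the two limits leave unreadable from compound 1 to compound 2 is therefore unreadable, because both values sit at the limit of > 63000 nM in this assay, at which 2 of the 2 values shown sit. Among the compounds with values here, compound 2 thus stands at the assay limit rather than at a measured number, and the one further value shown is the same limit.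

Compound 3 `COc1ccc(Cl)cc1S(=O)(=O)Nc1ccc(-c2nc3ccccc3o2)cc1` differs from compound 2 by 5-chloro-2-methoxyphenyl in place of 2-hydroxyphenyl on a sulfonyl sulfur. Within the data shown here, the only measured step, from compound 1 to compound 2, bears on this change in kind, since it also swaps the aryl group on the sulfonyl sulfur, but its size cannot be read. For compound 3 the expected step is a step that the limit leaves unreadable from compound 2 to compound 3, no change beyond the scatter. The estimate for compound 3 is 100000 nM, within 30000 nM to 300000 nM, most probably reported again only as a limit.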

Compound 3, half-maximal inhibitory concentration: > 63000 nM
Compound 3: a limit, no number; the forecaster's own chance of this, stated with the estimate: 80%; the middle value does not contradict the limit.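

In this assay compound 3 gives > 63000 nM as a limit of the assay. Within the data shown here, no step among compound 1, compound 2 and compound 3 can be read, because all three sit at the same limit: the limit of > 63000 nM in this assay, at which 3 of the 3 values shown sit. The compounds shown leave open whether changing the aryl group on the sulfonyl sulfur alters inhibition at all.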